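Working notes on compound 1 and compound 4

The source may report more compounds than this note shows. Statements on the series, on what has been measured and on what is new or still open speak of the compounds shown alone.

Values in a functional assay on DU-145 cells (Homo sapiens) for inhibition, read by trypan blue exclusion, with a stated time of 96 h (a lower number here means a stronger inhibitor of growth, a higher number a weaker inhibitor of growth), so far
- compound 1 `CN(C)c1ccc(/C=C(/Sc2ccccc2Br)C(=O)c2ccc(Br)cc2)cc1` gives > 100000 nM as a limit
- compound 2 `CN(C)c1ccc(/C=C(/SCc2ccc(F)cc2)C(=O)c2ccc(Br)cc2)cc1` gives 50000 nM as a number
- compound 3 `COc1ccc(/C=C(\C(=O)c2ccc(Br)cc2)S(=O)(=O)c2ccc(C)cc2)cc1` gives 1000 nM as a number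

Compound 1 stands at the limit of > 100000 nM in this assay, at which 1 of the 3 values shown sits, and so has no number. Compound 4 `O=C(/C(=C\c1c(O)cc(O)cc1O)Sc1ccccc1Br)c1ccc(Br)cc1` carries 2,4,6-trihydroxyphenyl in place of 4-(dimethylamino)phenyl on a double-bonded chain carbon bound to a double-bonded chain carbon and keeps the rest of compound 1. Within the data shown here, no measured step covers this place. Among the measured compounds shown here, the one measured step, an at least 2.0-fold lower number from compound 1 to compound 2 (0.30 log units; that floor lies within the scatter), changes a group on a sulfur and bears only loosely. Compound 3 at 1000 nM shows that a much lower number occurs among these compounds. The expected step in this assay is an at least 10-fold lower number from compound 1 to compound 4 (1.00 log units; beyond the scatter) toward a lower number, on thin grounds. For compound 4 the estimate is 10000 nM with an expected range from 1000 nM to 80000 nM as a wide one.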

Compound 4, concentration for 50% growth inhibition: > 100000 nM
Compound 4: no number, only a limit; the forecaster's own chance of this, stated with the estimate: 20%; at least 10-fold (1.00 log units) between middle value and limit.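

Among these compounds, compound 1 and compound 4 each give a limit and not a number, so no step between them can be read: the limit of > 100000 nM in this assay, at which 2 of the 4 values shown sit. The compounds shown leave open whether 2,4,6-trihydroxyphenyl in place of 4-(dimethylamino)phenyl changes growth inhibition at all.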